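Compound 2 to compound 4: ethoxy to hydroxy

A few compounds are considered here, and "the series" means these few. Any claim that something is new, unique, unknown or untested is made for them only; others in the source may bear on it.

Three compounds carry the ethoxycarbonyl end of the series in a functional assay on MOLT-4 cells (Homo sapiens) for inhibition, read by MTT assay, with a stated time of 48 h; a lower number here means a stronger inhibitor, a higher number a weaker inhibitor. Compound 1 `C/C=C/Cn1cc(/C=C/C(=O)CC(=O)C(=O)OCC)c2ccccc21` has the entry "not determined" (no result reported), and compound 3 `CCOC(=O)C(=O)CC(=O)/C=C/c1cn(Cc2ccc(OC)cc2)c2ccccc12` has the entry "not determined" (no result reported). Compound 2 `CCOC(=O)C(=O)CC(=O)/C=C/c1cn(Cc2ccccc2)c2ccccc12` reads > 40000 nM, which is a limit of the assay and not a number. Compound 4 `O=C(/C=C/c1cn(Cc2ccccc2)c2ccccc12)CC(=O)C(=O)O` has hydrogen in place of ethyl on an oxygen next to a carbonyl group. For the measured compounds named here, no measured pair shows this change, so the only anchor is the limit of > 40000 nM in this assay, at which 1 of the 3 values shown sits. The expected change is a number no higher from compound 2 to compound 4 (the limit leaves the size open), a step no larger than the scatter, with no direction foreseen. Compound 4 is estimated at 40000 nM, with an expected range of 12000 nM to 100000 nM.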

Compound 4, half-maximal inhibitory concentration: 15000 nM
Compound 4: the middle estimate sits 2.7-fold (0.43 log units) above what was measured, and the stated range covers the measured number.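

Ethoxy to hydroxy on this carbonyl gives the first number at this end of the chain in this assay, where compound 4 gives 15000 nM. The change from ethyl to hydrogen reads as an at least 2.6-fold lower number from compound 2 to compound 4 (0.42 log units; beyond the scatter). That step is only a lower bound, since it rests on a limit of the assay and not on a number: the limit of > 40000 nM in this assay, at which 1 of the 4 values shown sits.

From the compounds shown here alone, it remains open whether an amide or a methyl ester at this place would read like compound 2 or like compound 4. Going by these compounds, whether the step holds with other groups on the shared core also remains open.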